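The source may report more compounds than this note shows. Statements on the series, on what has been measured and on what is new or still open speak of the compounds shown alone.

Measured compounds:
compound 1, `Cc1ccc(C(=O)/C=C/c2ccc(/C=N/NC(=O)c3ccncc3)cc2)c(C)c1` — 58.5%
compound 2, `Cc1ccc(C(=O)/C=C/c2ccc(/C=N/NC(=N)N)cc2)cc1` — 77.7%
compound 3, `O=C(N/N=C/c1ccc(/C=C/C(=O)c2ccccc2F)cc1)c1ccncc1` — 51.3%

In a functional assay on the whole organism (Ear) for inhibition, with Mus musculus as the target, with a stated time of 30 min, at a dose of 100 mg/kg by the intraperitoneal route (on this read-out higher numbers stand for more inhibition at the one dose given (going by the name of the read-out) and lower numbers for less inhibition), compound 2 gives 77.7%, the highest of the three numbers; compound 1 stands beyond the scatter below it, and compound 3 further still. Among the compounds with values here, the one step recorded between measured compounds is a number 7.2 percentage points lower from compound 1 to compound 3 (within the scatter), a change of the aromatic ring on the carbonyl carbon that left the read-out within the scatter.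

Compound 4, `N=C(N)N/N=C/c1ccc(/C=C/C(=O)c2ccc(Cl)cc2)cc1`, differs from compound 2 by chloro in place of methyl on an aromatic carbon. This change also sits on the aromatic ring attached to the carbonyl carbon, the same region altered in the step from compound 1 to compound 3, which stayed within the scatter. Within the data shown here, no measured step bears on the chloro group itself. On that basis the account expects no step beyond the scatter in this assay, with the estimated change being a number 2.7 percentage points lower from compound 2 to compound 4 (within the scatter). Compound 4 is therefore estimated at 75%, in a range from 60% to 88%.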

Compound 4, a percentage reported as inhibition, in the whole organism at one dose (the size of the read-out at that dose, not a potency): 56.4%
Compound 4: the middle estimate sits 18.6 percentage points above what was measured, outside the stated range (below it).
By their numbers in this assay, from the lowest: compounds 3, 4 and 1 (each within the scatter of the next); then compound 2.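

The change from 4-methylphenyl to 4-chlorophenyl, with the rest of the structure unchanged, gives a number 21.3 percentage points lower from compound 2 to compound 4 (beyond the scatter) in this assay and is the first step shown to pass beyond the scatter on this ring. The earlier step on the ring attached to the carbonyl carbon, a number 7.2 percentage points lower from compound 1 to compound 3 (within the scatter), had not shown that the read-out can respond to a change here, and the new step shows that exchanging a single heavy atom is enough. Nothing measured for these compounds accounts for this loss of inhibition.

On these data alone, whether a methoxy group or an amine at this place would give a similar step remains open. As far as these compounds go, it is also open whether chloro in place of methyl would have the same effect on compound 1, which carries a different group at the other end of the molecule.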